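The compounds below may be only part of what the source reports. "The series", "measured", "known", "first", "only" and "open" are said of these compounds alone.

Among the compounds with values here, compound 2 `COc1ccc(C(=O)NN2C(=O)NC3(CC3(C)C)C2=O)cc1` holds the lower of the two numbers measured so far: in a functional assay on the whole organism (Hindlimb) for inhibition, with Mus musculus as the target, with a stated time of 0.5 h (on this read-out lower numbers stand for an effect already at smaller amounts and higher numbers for an effect only at larger amounts of compound), compound 2 gives 100 mg/kg, while compound 1 `CC1(C)CC12NC(=O)N(NC(=O)c1ccc(Br)cc1)C2=O` gives 300 mg/kg. Within the data shown here, the gap between them, a 3.0-fold lower number from compound 1 to compound 2 (0.48 log units; beyond the scatter), is the only measured step. Compound 3 `COc1ccc(C(=O)NN2C(=O)NC3(CC3(C)C)C2=O)cc1OC` differs from compound 2 by methoxy in place of hydrogen on an aromatic carbon, the entering methoxy sitting ortho to a methoxy group. Among the measured compounds shown here, no measured step swaps hydrogen for methoxy, so the one step, which concerned bromo, gives no direction here, and a change no larger than the scatter is expected. Compound 3 is estimated at 100 mg/kg, between 50 mg/kg and 300 mg/kg. The expected step is no change at the digits printed from compound 2 to compound 3 (within the scatter).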

Compound 3, minimum effective dose: 300 mg/kg
Estimate against measurement, compound 3: 3.0-fold (0.48 log units) below; the range from low to high includes it.
By their numbers in this assay, from the lowest: compound 2; then compounds 1 and 3 (each within the scatter of the next).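

In this assay, methoxy in place of hydrogen on this aromatic carbon, ortho to a methoxy group, gives a 3.0-fold higher number from compound 2 to compound 3 (0.48 log units; beyond the scatter), so more compound is needed for an effect. This position is therefore not indifferent to substitution: in this one pair, the added methoxy moves the number the wrong way. Nothing measured here explains the change. On these data alone, whether a hydroxyl, an amine or a longer chain such as ethoxy on this carbon would shift the number the same way stays open. So does whether the step would repeat with bromo in place of the existing methoxy.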